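The compounds below may be only part of what the source reports. "The series", "measured", "known", "first", "only" and "open" are said of these compounds alone.

Of the compounds shown here, two carry measured values so far. Compound 1 `Cc1cc(NC(=O)Cn2nnc(-c3cccnc3)n2)n(C2CCCCC2)n1` bears pyridin-3-yl on the shared core, and compound 2 `Cc1cc(NC(=O)Cn2nnc(-c3cccc(Cl)c3)n2)n(C2CCCCC2)n1` bears 3-chlorophenyl in that position. In an assay on HEK293 cells for activation of Kir3.1/Kir3.2 (Homo sapiens), read by thallium flux (on this read-out lower numbers stand for smaller maximal responses and higher numbers for larger maximal responses), compound 1 gives 96%, and compound 2 gives 89%. Among the measured compounds shown here, the single measured step, a number 7 percentage points lower from compound 1 to compound 2 (within the scatter), does not separate the two compounds, so compound 2 cannot be told apart from compound 1 on these numbers; it simply stands beside compound 1 within the scatter of the assay.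

Compound 3 `Cc1cc(NC(=O)Cn2nnc(-c3ccc(F)cc3)n2)n(C2CCCCC2)n1` is the next member. Its structure differs from compound 2 in one place: 4-fluorophenyl in place of 3-chlorophenyl on an aromatic carbon. For the measured compounds named here, no measured step exchanges one substituted phenyl for another, and the only step on record, a number 7 percentage points lower from compound 1 to compound 2 (within the scatter), concerned a different exchange at the same position and stayed within the scatter. On that basis no step beyond the scatter is expected in this assay for compound 3. The value for compound 3 is estimated at 88%, with a range from 72% to 100%. The expected step from compound 2 is therefore a number 1 percentage points lower from compound 2 to compound 3 (within the scatter).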

Compound 3, largest response reached (Emax), in percent of the reference or control that the assay uses: 92%
Estimate against measurement, compound 3: 4 percentage points below; the measured number falls inside the stated range.
By their numbers in this assay, from the lowest: compounds 2, 3 and 1 (each within the scatter of the next).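

Among the compounds shown here, the step of a number 3 percentage points higher from compound 2 to compound 3 (within the scatter) in this assay is the first measured exchange of one substituted phenyl for another at this position, and it shows that going from 3-chlorophenyl to 4-fluorophenyl, which alters both the halogen and the name's ring number, does not separate the two compounds. The step of a number 4 percentage points lower from compound 1 to compound 3 (within the scatter) adds a second comparison of pyridin-3-yl with a halogen-bearing phenyl, so that pyridin-3-yl, 3-chlorophenyl and 4-fluorophenyl now all stand within the scatter of one another on this read-out, with no order among them. No independent evidence bears on this result, so nothing can be said about what lies behind these numbers.

On these data alone, the three compounds all carry a six-membered aromatic ring at this position, so it remains open whether any exchange here can give a step beyond the scatter. A carboxylic acid, an amine or a longer alkyl chain in place of the aromatic ring would test this, and the methyl and cyclohexyl groups elsewhere on the shared core remain constant throughout these compounds.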